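Working notes: E and Z forms of compound 1

The source may report more compounds than this note shows. Statements on the series, on what has been measured and on what is new or still open speak of the compounds shown alone.

- compound 1 `C=C(Br)C(=O)Nc1ccc2c(c1)/C(=C\c1ccsc1)C(=O)N2` gives 310 nM
- compound 2 `C=C(Br)C(=O)Nc1ccc2c(c1)/C(=C\c1sccc1C)C(=O)N2` gives 330 nM

For the measured compounds named here, these values come from a functional assay on HT-29 cells (Homo sapiens) for antiproliferative activity, read by MTT assay, with a stated time of 72 h (a higher number here means a weaker inhibitor, a lower number a stronger inhibitor), and compound 1 sits within the scatter of compound 2, the only other measured compound. Compound 3 `C=C(Br)C(=O)Nc1ccc2c(c1)/C(=C/c1ccsc1)C(=O)N2` is the next to be read against compound 1 (the two compounds have the same atoms and bonds and differ only in configuration as drawn: 1 of 1 stereo elements differ; a double bond is drawn E in compound 1 and Z in compound 3): a double bond is drawn E in compound 1 and Z in compound 3. Going by the values given here, the only measured step (a 1.1-fold higher number from compound 1 to compound 2 (0.03 log units; within the scatter)) puts 3-methylthiophen-2-yl in place of thiophen-3-yl, and no measured pair tests configuration. It therefore bears on compound 3 only weakly. The data give no direction in this assay and no step beyond the scatter is expected, though with wide margins. The expected step is a 1.1-fold higher number from compound 1 to compound 3 (0.05 log units; within the scatter) as an estimate only. For compound 3 the estimated value is 350 nM (expected range 120 nM to 1000 nM).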

Compound 3, half-maximal inhibitory concentration: 600 nM
Compound 3: middle estimate off by 1.7-fold (0.23 log units), on the low side, and the stated range covers the measured number.
By their numbers in this assay, from the lowest: compounds 1, 2 and 3 (each within the scatter of the next).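

In this assay, for the compounds shown here, moving the double bond from E to Z gives a 1.9-fold higher number from compound 1 to compound 3 (0.29 log units; within the scatter), the first reading on configuration at this position. On this single pair, the two drawn forms cannot be separated beyond the scatter, so configuration at this double bond shows no established effect on the antiproliferative read-out with thiophen-3-yl in place. The reading can be assigned to configuration alone and not to any other structural change: the fact that compounds 1 and 3 differ only in the configuration as drawn.

Whether the same holds with 3-methylthiophen-2-yl on the double bond remains open, as compound 2 has no counterpart of opposite configuration among the compounds shown. Also open, from the compounds shown here alone, is how a phenyl or a pyridine ring in place of thiophen-3-yl would read in this assay in either configuration.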